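This account rests on a few compounds, and the source may have more. Where it says the series, first, only, none or still open, it means among the compounds named here.

Measured compounds:
compound 1 `C=C1CC(CBr)(c2ccccc2)OC1=O`: 1480 nM
compound 2 `C=C1CC(CBr)(c2ccccc2C)OC1=O`: 5500 nM
compound 3 `C=C1CC(CBr)(c2ccccc2OC)OC1=O`: 2400 nM

All three numbers come from a functional assay on A-431 cells (Homo sapiens) for antiproliferative activity, read by sulforhodamine B assay, with a stated time of 72 h; on this read-out lower numbers stand for stronger inhibition and higher numbers for weaker inhibition. Compound 3 gives the second highest of the three; its nearest neighbour is compound 1, with a 1.6-fold higher number from compound 1 to compound 3 (0.21 log units; within the scatter), and its furthest is compound 2, with a 2.3-fold lower number from compound 2 to compound 3 (0.36 log units; beyond the scatter).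

Compound 4 `C=C1CC(CBr)(c2ccccc2F)OC1=O` differs from compound 3 in one place: fluoro in place of methoxy on an aromatic carbon. For the measured compounds named here, the change swaps one substituent on the aromatic carbon ortho to a group of 9 heavy atoms for another, so the steps that bear on it are those among compounds 1, 2 and 3, which all vary that same carbon. Compound 1 carries hydrogen there; a 1.6-fold higher number from compound 1 to compound 3 (0.21 log units; within the scatter) shows methoxy leaving the number about where hydrogen puts it, whereas a 3.7-fold higher number from compound 1 to compound 2 (0.57 log units; beyond the scatter) shows methyl raising it. Fluoro brings 1 heavy atom and 0 hydrogen-bond acceptors where methoxy brought 2 heavy atoms and 1 acceptor, closer in bulk to hydrogen than to methyl. Compound 4 is therefore expected to sit between the values of compound 1 and compound 3, and any shift should stay within the scatter. For compound 4 the expected outcome is a 1.3-fold lower number from compound 3 to compound 4 (0.12 log units; within the scatter). Compound 4 is estimated at 1800 nM, with a range from 900 nM to 3600 nM.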

Compound 4, half-maximal inhibitory concentration: 1700 nM
Compound 4: middle estimate off by 1.1-fold (0.02 log units), on the high side; the measured number falls inside the stated range.
By their numbers in this assay, from the lowest: compounds 1, 4 and 3 (each within the scatter of the next); then compound 2.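

In this assay, fluoro on the aromatic carbon ortho to a group of 9 heavy atoms groups with hydrogen and with methoxy: a 1.1-fold higher number from compound 1 to compound 4 (0.06 log units; within the scatter) and a 1.4-fold lower number from compound 3 to compound 4 (0.15 log units; within the scatter) place all three substituents within the scatter of one another. Methyl is now the only one of the four groups at this carbon that stands apart, as a 3.2-fold lower number from compound 2 to compound 4 (0.51 log units; beyond the scatter) adds a third step beyond the scatter to a 3.7-fold higher number from compound 1 to compound 2 (0.57 log units; beyond the scatter) and a 2.3-fold lower number from compound 2 to compound 3 (0.36 log units; beyond the scatter). The hydrogen-bond acceptor count does not separate the values at this carbon, since compound 3 with its methoxy acceptor stays within the scatter of compound 1 and compound 4, whose groups carry none.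

No evidence in hand bears on why methyl stands apart from hydrogen, fluoro and methoxy at this carbon.
The compounds shown leave open whether chloro, a hydroxyl group or an amine on the same carbon would group with methyl or with the other three, and whether fluoro on another carbon of the aromatic ring would give a value in the same range.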